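Compound 4: amino in place of benzyloxy

The source may hold more compounds than are shown below. What is called first, only, known or untested is meant among the compounds shown, and "the series" means these compounds.

Among the compounds with values here, in a functional assay on SEM cells (Homo sapiens) for inhibition, read by MTT assay, with a stated time of 72 h (a higher number here means a weaker inhibitor, a lower number a stronger inhibitor), compound 1 `COc1cc(NC(=O)/C=C/c2cccc(OCc3ccccc3)c2)cc(OC)c1OC` gives 8500 nM, the highest of the three numbers so far. Compound 2 `C=C(Br)C(=O)Nc1cccc(/C=C/C(=O)Nc2cccc(F)c2)c1` gives 620 nM and compound 3 `C=C(Br)C(=O)Nc1cccc(/C=C/C(=O)NCc2ccc(C)cc2)c1` gives 1300 nM. Compound 4 `COc1cc(NC(=O)/C=C/c2cccc(N)c2)cc(OC)c1OC` keeps the core of compound 1 but carries amino in place of benzyloxy on an aromatic carbon.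

Within the data shown here, only one measured step is available, a 2.1-fold higher number from compound 2 to compound 3 (0.32 log units; beyond the scatter), and it is modest. That step concerns a group on an amide-type nitrogen rather than an aromatic carbon, so it offers only a loose guide to size. Among the measured compounds shown here, no measured pair tests the loss of benzyloxy. A step of at least similar size is therefore expected in this assay, leaning towards a higher number, though this direction is tentative. The estimated step is a 2.1-fold higher number from compound 1 to compound 4 (0.33 log units; beyond the scatter). For compound 4 the expected value is 18000 nM, with an estimated range of 6000 nM to 50000 nM.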

Compound 4, half-maximal inhibitory concentration: 2810 nM
Beside the measured number, compound 4's estimate is 6.4-fold (0.81 log units) above it; the measured number lies below the stated range.
By their numbers in this assay, from the lowest: compound 2; then compound 3; then compound 4; then compound 1.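

In this assay this aromatic carbon, meta to a large group, does not depend on benzyloxy: exchanging that group, with its six-membered aromatic ring, for amino gives a 3.0-fold lower number from compound 1 to compound 4 (0.48 log units; beyond the scatter). Within the data shown here, this is the first measured change at this position, and it shows that the single heavy atom of amino is enough on the core of compound 1, with a modest gain rather than a loss. Nothing available accounts for why the number falls.

The compounds shown leave open whether the lower number follows from the loss of benzyloxy or from the arrival of amino, a question that a hydroxyl or methoxy group on this carbon would bear on. From the compounds shown here alone, it also remains open how far the trend extends to larger groups on the amino nitrogen, such as an acetyl or a bromoacryloyl group.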